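A Ring-Closed Amine in Place of the Butylamine Chain

The source may hold more compounds than are shown below. What is called first, only, known or untested is meant among the compounds shown, and "the series" means these compounds.

Of the compounds shown here, two that share one core have been measured in an assay on isolated protein for inhibition of Myeloperoxidase (Homo sapiens); on this read-out higher numbers stand for weaker inhibition and lower numbers for stronger inhibition. Compound 1 `NCc1ccc(-n2cc(-c3ccc4cc[nH]c4c3)c(C(F)(F)F)n2)cc1` gives 360 nM in this assay, and compound 2 `NCCCCn1cc(-c2ccc3cc[nH]c3c2)c(C(F)(F)F)n1` gives 900 nM. Of these two numbers compound 2 carries the higher one, and the step of a 2.5-fold higher number from compound 1 to compound 2 (0.40 log units; beyond the scatter) records what happened when the 4-aminobutyl chain took the place of the 4-(aminomethyl)phenyl group on the aromatic nitrogen. Compound 3 `N[C@@H]1CC[C@@H](n2cc(-c3ccc4cc[nH]c4c3)c(C(F)(F)F)n2)C1` has not yet been measured. It differs from compound 2 in one place: a group of 6 heavy atoms (5 carbon, 1 nitrogen; one five-membered non-aromatic ring of carbon only) in place of a group of 5 heavy atoms (4 carbon, 1 nitrogen; no ring), on an aromatic nitrogen. Within the data shown here, the only measured step that touches this position is a 2.5-fold higher number from compound 1 to compound 2 (0.40 log units; beyond the scatter), a modest one, and it compares an open chain with an aromatic arm rather than with a five-membered non-aromatic ring carrying two defined stereocentres, so there is no direct precedent. The expected step is therefore a 1.8-fold lower number from compound 2 to compound 3 (0.26 log units; within the scatter), landing between the two measured numbers rather than beyond them. Compound 3 is expected to give 500 nM in this assay, within a range from 150 nM to 1600 nM.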

Compound 3, half-maximal inhibitory concentration in the Myeloperoxidase assay: 170 nM
Beside the measured number, compound 3's estimate is 2.9-fold (0.47 log units) above it; the range from low to high includes it.
By their numbers in the Myeloperoxidase assay, from the lowest: compound 3; then compound 1; then compound 2.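

In the Myeloperoxidase assay, closing the open 4-aminobutyl chain into a five-membered carbon ring that carries the amine brings a 5.3-fold lower number from compound 2 to compound 3 (0.72 log units; beyond the scatter) and so shows that the group on this aromatic nitrogen still matters when the amine stays and the counts of hydrogen-bond donors and acceptors do not change. Set against the 4-(aminomethyl)phenyl group, the same non-aromatic ring gives in the Myeloperoxidase assay a 2.1-fold lower number from compound 1 to compound 3 (0.33 log units; beyond the scatter) and so shows that an aromatic ring on this nitrogen is not needed for the lowest number of the three. The ring also moves the number in a physicochemical assay for solubility, at pH 6.8 (a higher number here means a more soluble compound, a lower number a less soluble compound), in a favourable direction, since compound 2 gives 73000 nM and compound 3 gives 587000 nM: the measured solubility of compound 2, 73000 nM, and of compound 3, 587000 nM, an 8.0-fold higher number (0.91 log units; beyond the scatter)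

The compounds shown cannot tell whether the lower number belongs to the five-membered ring as such or to this particular arrangement of its two stereocentres. Nor do they tell how a six-membered carbon ring bearing the same amine, or a piperidine ring holding the nitrogen within the ring, would behave on this aromatic nitrogen in the Myeloperoxidase assay.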